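This account rests on a few compounds, and the source may have more. Where it says the series, first, only, none or still open, it means among the compounds named here.

Compound 1 `Nc1cc(N)c2nc(-c3ccccc3)c(NCc3ccc(Cl)c(Cl)c3)nc2c1` stands as the compound with the lowest number of the three measured in a functional assay on RXF 393 cells (Homo sapiens) for inhibition, read by sulforhodamine B assay, with a stated time of 48 h (on this read-out lower numbers stand for stronger inhibition of growth and higher numbers for weaker inhibition of growth), where compound 1 gives 3090 nM. Its nearest neighbour on this read-out is compound 3 `CCOC(=O)[C@H](CCC(=O)O)NC(=O)c1ccc(Oc2nc3cc(N)cc(N)c3nc2-c2ccccc2)cc1`; in this assay compound 3 gives 7410 nM, a gap beyond the scatter. Furthest from compound 1 lies compound 2 `Nc1cc(N)c2nc(-c3ccccc3)c(Oc3ccc(F)cc3)nc2c1`, which gives 19100 nM in this assay, again a gap beyond the scatter. Compound 4 `COc1ccc(CNc2nc3cc(N)cc(N)c3nc2-c2ccccc2)cc1` has not yet been measured in this assay. It differs from compound 1 in one place: 4-methoxyphenyl in place of 3,4-dichlorophenyl on a saturated chain carbon bound to a nitrogen on an aromatic ring. No measured pair among these compounds shares this change, so any expectation for compound 4 rests only on the position of compound 1 and on the nature of the exchange at the saturated chain carbon bound to a nitrogen on an aromatic ring. The expected step, a 1.9-fold higher number from compound 1 to compound 4 (0.29 log units; within the scatter), is modest and runs toward weaker inhibition of growth, possibly at the edge of the scatter rather than clearly beyond it. In this assay compound 4 is therefore expected to give about 6000 nM, with a plausible range from 2000 nM to 18000 nM.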

Compound 4, concentration for 50% growth inhibition: 5370 nM
The estimate for compound 4 lay 1.1-fold (0.05 log units) above the measured number; low and high end bracket the measured number.
By their numbers in this assay, from the lowest: compounds 1, 4 and 3 (each within the scatter of the next, the first and the last beyond it); then compound 2.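

In this assay, for the compounds shown here, the earlier compounds offered no pair differing in one place, so the group on the saturated chain carbon bound to a nitrogen on an aromatic ring could not be read on its own. The exchange of 3,4-dichlorophenyl for 4-methoxyphenyl gives a 1.7-fold higher number from compound 1 to compound 4 (0.24 log units; within the scatter) and so provides the first such reading: in this one pair, a group with two chlorine atoms and no hydrogen-bond acceptor gives way to one with an oxygen and one hydrogen-bond acceptor, with no difference that stands clear of the scatter. No measurement at hand accounts for this result or ties it to any property of either group.

This single pair leaves open whether other groups at this place would also stay within the scatter of compound 1, for example an unsubstituted phenyl, a pyridine or a morpholine. It also leaves open what a longer chain would do in place of the single saturated chain carbon, or an amine or a carboxylic acid carried on the ring.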